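Galloyl Glucosides: From a Terpene to an Aryl Aglycone

The source may hold more compounds than are shown below. What is called first, only, known or untested is meant among the compounds shown, and "the series" means these compounds.

Three glucosides bearing a galloyl ester were measured in a functional assay, read by spectrophotometry, with a stated time of 30 min, tested at 20 uM; on this read-out lower numbers stand for a weaker effect and higher numbers for a stronger effect at the one concentration tested. Compound 1 `CC1=CC[C@@H](C(C)(C)O[C@@H]2O[C@H](COC(=O)c3cc(O)c(O)c(O)c3)[C@@H](O)[C@H](O)[C@H]2O)CC1` gives 88.9%. Compound 2 `COc1cc(CC(CO)O[C@@H]2O[C@H](COC(=O)c3cc(O)c(O)c(O)c3)[C@@H](O)[C@H](O)[C@H]2O)ccc1O` gives 92.4%, and compound 3 `C=CCc1cc(OC)c(O)c(O[C@@H]2O[C@H](COC(=O)c3cc(O)c(O)c(O)c3)[C@@H](O)[C@H](O)[C@H]2O)c1` gives 91.2%. Compound 1 has the lowest of the three numbers, yet its gaps to compound 3 and to compound 2 both lie within the scatter, so no order among them can be claimed. Compound 4 `C=CCc1ccc(O[C@@H]2O[C@H](COC(=O)c3cc(O)c(O)c(O)c3)[C@@H](O)[C@H](O)[C@H]2O)c(OC)c1` has not been measured. It differs from compound 1 in one place: 4-allyl-2-methoxyphenyl in place of 1-methyl-1-(4-methylcyclohex-3-en-1-yl)ethyl on an oxygen on a saturated carbon. For the measured compounds named here, no step between measured compounds is available, and the three measured numbers sit close together, so the step of a number 1.1 percentage points higher from compound 1 to compound 4 (within the scatter) is expected to stay within the scatter. Compound 4 is therefore estimated at 90%, between 82% and 96%.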

Compound 4, a percentage reported as activity, at one concentration (the size of the read-out at that concentration, not a potency): 95.2%
Compound 4: middle estimate off by 5.2 percentage points, on the low side; the range from low to high includes it.
By their numbers in this assay, from the lowest: compounds 1, 3, 2 and 4 (each within the scatter of the next).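

In this assay the exchange of 1-methyl-1-(4-methylcyclohex-3-en-1-yl)ethyl for 4-allyl-2-methoxyphenyl on an oxygen on a saturated carbon gives a number 6.3 percentage points higher from compound 1 to compound 4 (within the scatter) and so shows that this position accepts an aromatic ring in place of a non-aromatic ring without a difference beyond the scatter. For the compounds shown here, it is the only one-place comparison here, and it rests on a single pair. Nothing available explains the read-out at this position. From the compounds shown here alone, whether a simple alkyl chain, an amine or a carboxylic acid at this position would keep the read-out stays open. So does any difference among these compounds at lower concentrations.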